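Lengthening the Chain of Compound 3

This account rests on a few compounds, and the source may have more. Where it says the series, first, only, none or still open, it means among the compounds named here.

In a functional assay on ASPC1 cells (Homo sapiens) for cytotoxicity (on this read-out lower numbers stand for stronger inhibition and higher numbers for weaker inhibition), compound 1 (`O=C(CCCCCCC(=O)Nc1nc2ccccc2s1)NO`) gives 5.69 ug/mL and compound 2 (`O=C(CCCCCCC(=O)Nc1nc2ccc([N+](=O)[O-])cc2s1)NO`) gives 1.65 ug/mL on the same scale. Compound 3 (`CCOc1ccc2nc(NC(=O)CCCCC(=O)NO)sc2c1`) gives 16.7 ug/mL as the highest of the three numbers, so it is the weakest inhibitor measured so far. Compound 4 (`CCOc1ccc2nc(NC(=O)CCCCCCC(=O)NO)sc2c1`) departs from compound 3 by one change (2-(hydroxycarbamoyl)ethyl in place of hydroxycarbamoyl on a saturated chain carbon, four bonds along the chain from a carbonyl carbon), namely 2-(hydroxycarbamoyl)ethyl in place of hydroxycarbamoyl on a saturated chain carbon, four bonds along the chain from a carbonyl carbon. That gives compound 4 the chain of compound 1 and compound 2. For the measured compounds named here, the only measured step (a 3.4-fold lower number from compound 1 to compound 2 (0.54 log units; beyond the scatter)) is modest and comes from nitro in place of hydrogen on an aromatic carbon, so no measured step tests the chain change itself. The indirect hint is that compound 1 at 5.69 ug/mL and compound 2 at 1.65 ug/mL both sit under compound 3, though these compounds also differ elsewhere on the shared core. A lower number is therefore expected in this assay, with an estimated change (a 3.3-fold lower number from compound 3 to compound 4 (0.52 log units; beyond the scatter)) that stays uncertain. For compound 4 the estimate is 5 ug/mL within an expected range of 1.8 ug/mL to 14 ug/mL in that read-out.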

Compound 4, half-maximal inhibitory concentration: 9.88 ug/mL
Estimate against measurement, compound 4: 2.0-fold (0.30 log units) below; measured number inside the range.
By their numbers in this assay, from the lowest: compound 2; then compounds 1, 4 and 3 (each within the scatter of the next, the first and the last beyond it).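

In this assay, putting 2-(hydroxycarbamoyl)ethyl in place of hydroxycarbamoyl at this chain position gives (a 1.7-fold lower number from compound 3 to compound 4 (0.23 log units; within the scatter)), so with ethoxy on the shared core the chain change alone does not clearly separate the two compounds. With the chain held at that of compound 4, the aromatic group can now be read: ethoxy and hydrogen cannot be told apart (a 1.7-fold higher number from compound 1 to compound 4 (0.24 log units; within the scatter)), while ethoxy and nitro can (a 6.0-fold higher number from compound 2 to compound 4 (0.78 log units; beyond the scatter)). Nothing measured here offers a reason for these numbers.

The compounds shown leave open whether the same chain change would count for more with nitro or hydrogen in place of ethoxy on the aromatic carbon. In this assay they also leave open how a longer chain, or a carboxylic acid in place of hydroxycarbamoyl, would compare.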